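A few compounds are considered here, and "the series" means these few. Any claim that something is new, unique, unknown or untested is made for them only; others in the source may bear on it.

Compound 1 `CCCn1c(Cc2cc(OC)c(OC)c(OC)c2)nc2c(N)ncnc21`: 46800 nM
Compound 2 `C/C=C/Cn1c(Cc2cc(OC)c(OC)c(OC)c2)nc2c(N)ncnc21`: 51300 nM

In a functional assay on MCF7 cells (Homo sapiens) for antiproliferative activity (on this read-out lower numbers stand for stronger inhibition and higher numbers for weaker inhibition), compound 2 holds the highest of the two numbers, with compound 1 close by, the gap within the scatter. Compound 3 `COc1cc(Cc2nc3c(N)ncnc3n2CCOC(C)C)cc(OC)c1OC` differs from compound 2 in one place: isopropoxymethyl in place of prop-1-en-1-yl on a saturated chain carbon bound to an aromatic nitrogen. Going by the values given here, the only measured step at this position, a 1.1-fold higher number from compound 1 to compound 2 (0.04 log units; within the scatter), stayed within the scatter, so the chain bound to the aromatic nitrogen has so far made little difference. The step to compound 3 is therefore expected to be a 1.0-fold lower number from compound 2 to compound 3 (0.01 log units; within the scatter), not beyond the scatter. Compound 3 is estimated at 50000 nM, with a range from 20000 nM to 120000 nM.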

Compound 3, half-maximal inhibitory concentration: 38900 nM
Beside the measured number, compound 3's estimate is 1.3-fold (0.11 log units) above it; the measured number falls inside the stated range.
By their numbers in this assay, from the lowest: compounds 3, 1 and 2 (each within the scatter of the next).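

In this assay, isopropoxymethyl, a larger group carrying a hydrogen-bond acceptor, can stand in place of prop-1-en-1-yl with the number staying within the scatter (a 1.3-fold lower number from compound 2 to compound 3 (0.12 log units; within the scatter)). Isopropoxy in place of methyl gives the same picture (a 1.2-fold lower number from compound 1 to compound 3 (0.08 log units; within the scatter)). Across these three compounds, neither the double bond nor the ether oxygen separates the numbers, and no evidence is available to explain this. As far as these compounds go, whether an amine or a carboxylic acid on this chain would move the number beyond the scatter remains open.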